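The compounds below may be only part of what the source reports. "The series", "measured", "known", "first", "only" and "open" are said of these compounds alone.

Compound 1 `CCCC(=O)Nc1ccc(S(=O)(=O)Oc2ccccc2I)cc1`: in a functional assay on M21 cells (Homo sapiens) for antiproliferative activity, read by sulforhodamine B assay, with a stated time of 48 h (a lower number here means a stronger inhibitor, a higher number a weaker inhibitor), compound 1 gives 9000 nM.
Compound 2 `CC(C)C(=O)Nc1ccc(S(=O)(=O)Oc2ccccc2C(C)C)cc1`: in this assay compound 2 gives 11000 nM.

Compound 2 has the higher of the two numbers, but its gap to compound 1 lies within the usual scatter, so the two cannot be told apart here. Compound 3 `CC(C)C(=O)Nc1ccc(S(=O)(=O)Oc2ccccc2I)cc1` arises from compound 2 by iodo in place of isopropyl on an aromatic carbon. Among the compounds with values here, no measured pair shows this change on its own; compound 1 also carries iodo while differing elsewhere, and its number sits close to that of compound 2. For compound 3 the expected step of a 1.2-fold lower number from compound 2 to compound 3 (0.06 log units; within the scatter) is none beyond the scatter. Compound 3 is estimated at 9500 nM, with a range from 4000 nM to 22000 nM.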

Compound 3, half-maximal inhibitory concentration: 13000 nM
Compound 3: middle estimate off by 1.4-fold (0.14 log units), on the low side; measured number inside the range.
By their numbers in this assay, from the lowest: compounds 1, 2 and 3 (each within the scatter of the next).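

In this assay, iodo in place of isopropyl on this aromatic carbon gives a 1.2-fold higher number from compound 2 to compound 3 (0.07 log units; within the scatter), so these two groups cannot be told apart at this position, although iodo has one heavy atom and isopropyl has three. On the carbonyl carbon, isopropyl in place of propyl gives a 1.4-fold higher number from compound 1 to compound 3 (0.16 log units; within the scatter), so that change cannot be told apart from the scatter either. Nothing further on hand explains these results.

On these data alone, it remains open whether an amine or a carboxylic acid on that aromatic carbon would shift the number beyond the scatter. As far as these compounds go, a longer chain on the carbonyl carbon remains equally open.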